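Methyl for methoxy on the carbamoyl aryl group

This account rests on a few compounds, and the source may have more. Where it says the series, first, only, none or still open, it means among the compounds named here.

Three compounds were measured in a functional assay on the whole organism for inhibition, with Rattus norvegicus as the target, read by paw edema, with stated times of 30 min and 2 h, at a dose of 0.28 mmol/kg by the oral route; a higher number here means more inhibition at the dose given (going by the name of the read-out), a lower number less inhibition:

compound 1, `CNC(=O)c1nc(-c2cc(OC)c(OC)c(OC)c2)n(-c2ccc(OC)cc2)n1`, 74%
compound 2, `CCNC(=O)c1nc(-c2cc(OC)c(OC)c(OC)c2)n(-c2ccc(OC)cc2)n1`, 68%
compound 3, `COc1ccc(NC(=O)c2nc(-c3cc(OC)c(OC)c(OC)c3)n(-c3ccc(OC)cc3)n2)cc1`, 45%

Compound 3 stands lowest of the three. The step of a number 29 percentage points lower from compound 1 to compound 3 (beyond the scatter) and the step of a number 23 percentage points lower from compound 2 to compound 3 (beyond the scatter) both lie beyond the scatter, so compound 3 is set apart from the two alkyl amides, whereas the step of a number 6 percentage points lower from compound 1 to compound 2 (within the scatter) is within the scatter.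

Compound 4, `COc1ccc(-n2nc(C(=O)Nc3ccc(C)cc3)nc2-c2cc(OC)c(OC)c(OC)c2)cc1`, keeps the anilide of compound 3 and changes only the substituent on its aryl ring: methyl in place of methoxy on an aromatic carbon. For the measured compounds named here, no measured step touches this position; the measured steps all change what sits on the amide-type nitrogen, so they show what replacing an alkyl group by 4-methoxyphenyl does but say nothing about the methoxy itself. Going by the values given here, with no comparable step to lean on, compound 4 is expected to stay close to compound 3, with a step of no change at the digits printed from compound 3 to compound 4 (within the scatter) that does not go beyond the scatter in either direction. Compound 4 is therefore estimated at 45%, within a range of 30% to 60%.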

Compound 4, a percentage reported as inhibition, in the whole organism at one dose (the size of the read-out at that dose, not a potency): 60%
For compound 4 the middle estimate is 15 percentage points below the measured one; the measured number falls inside the stated range.
By their numbers in this assay, from the lowest: compound 3; then compounds 4, 2 and 1 (each within the scatter of the next, the first and the last beyond it).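

In this assay, for the compounds shown here, the substituent on the anilide ring turns out to matter by itself: methyl in place of methoxy gives a clear change (a number 15 percentage points higher from compound 3 to compound 4 (beyond the scatter)), whereas the earlier steps changed only what sits on the amide-type nitrogen and could not separate the effect of the aryl ring from that of its methoxy. The distance between the anilide and the alkyl amides also depends on this substituent, since 4-methylphenyl in place of ethyl stays close (a number 8 percentage points lower from compound 2 to compound 4 (within the scatter)), while 4-methylphenyl in place of methyl still leaves a gap (a number 14 percentage points lower from compound 1 to compound 4 (beyond the scatter)), so the separation of compound 3 from both alkyl amides does not carry over in full to compound 4. Nothing at hand bears on the reason for the step from methoxy to methyl.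

With only methoxy and methyl seen at this position, the compounds shown do not tell whether a chlorine atom, a hydroxyl group, an amine or a longer chain such as propyl would follow the methyl or the methoxy. They also leave open whether the same exchange would have any comparable result at the other methoxy groups of the shared core.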